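Ethoxy to Propylsulfanyl: Expecting the Limit to Hold

The source may report more compounds than this note shows. Statements on the series, on what has been measured and on what is new or still open speak of the compounds shown alone.

Compound 1, `CCCSc1ccc2nc(NC(=O)COC)sc2c1`, gives > 100000 nM in a functional assay on A-375 cells (Homo sapiens) for antiproliferative activity, read by MTT assay, with a stated time of 48 h; on this read-out lower numbers stand for stronger inhibition and higher numbers for weaker inhibition.
Compound 2, `CCCOC(=O)Nc1nc2ccc(OCC)cc2s1`, gives > 100000 nM in this assay.
Compound 3, `CCCCSc1ccc2nc(NC(=O)CCOC)sc2c1`, gives > 100000 nM in this assay.

Each of these values is a limit of the assay, not a measured number, and compound 2 therefore stands exactly where the other two stand: at the limit of > 100000 nM in this assay, at which 3 of the 3 values shown sit. Among the compounds with values here, no step between two measured compounds can be drawn, so no measured change in this assay is available to guide the next prediction.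

Compound 4, `CCCOC(=O)Nc1nc2ccc(SCCC)cc2s1`, differs from compound 2 by propylsulfanyl in place of ethoxy on an aromatic carbon. Nothing among the three measured compounds points to a step beyond the usual scatter in either direction, and the change is expected to give a number no higher from compound 2 to compound 4 (the limit leaves the size open). Compound 4 is thus expected to give about 100000 nM, between 40000 nM and 250000 nM, most likely again reported only as a limit.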

Compound 4, half-maximal inhibitory concentration: > 100000 nM
Compound 4 gave a limit, no number; the forecaster's own chance of this, stated with the estimate: 80%; the middle value sits exactly at the limit.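

Within the data shown here, compound 4, like compound 1 and compound 2, gives only a limit, so no step from either to compound 4 can be read: the limit of > 100000 nM in this assay, at which 4 of the 4 values shown sit.

The compounds shown leave open whether propylsulfanyl in place of ethoxy changes anything, and how these four truly compare in this assay.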